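Replacing 4-phenylphenyl with hexyl on a triple-bonded carbon

The source may report more compounds than this note shows. Statements on the series, on what has been measured and on what is new or still open speak of the compounds shown alone.

Compound 1 `CCC/C=C/C=C/c1cc(C#N)ccc1COC(c1ccc(C#N)cc1)c1cncn1C`: 16.7 nM
Compound 2 `Cn1cncc1C(OCc1ccc(C#N)cc1C#Cc1ccc(-c2ccccc2)cc1)c1ccc(C#N)cc1`: > 0.1 nM

In a functional assay on NIH3T3 cells (Mus musculus) (on this read-out lower numbers stand for an effect already at smaller amounts and higher numbers for an effect only at larger amounts of compound), compound 1 gives 16.7 nM. Compound 2 is reported only as a limit, > 0.1 nM, and not as a number. Compound 3 `CCCCCCC#Cc1cc(C#N)ccc1COC(c1ccc(C#N)cc1)c1cncn1C` carries hexyl in place of 4-phenylphenyl on a triple-bonded carbon. For the measured compounds named here, no measured step connects these compounds, so the expectation in this assay is uncertain. It rests on compound 1, which also carries a chain without a ring and gives 16.7 nM. A move to a larger number is expected, with the estimated step being a step that the limit leaves unreadable from compound 2 to compound 3. For compound 3 the estimate is 10 nM, with an expected range of 2 nM to 50 nM.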

Compound 3, half-maximal effective concentration: > 0.1 nM
Compound 3: no number, only a limit (the forecaster's own chance of this, stated with the estimate: 10%); the middle value does not contradict the limit.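

For the compounds shown here, compound 3, like compound 2, is reported in this assay only as a limit, so no step to compound 3 from compound 1 or compound 2 can be read. The compounds shown leave open how far hexyl in place of 4-phenylphenyl on a triple-bonded carbon shifts the read-out.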